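The compounds below may be only part of what the source reports. "The series", "measured", "known", "first", "only" and "open" are said of these compounds alone.

Compound 1 `Nc1nc(Cl)c2ncn(Cc3ccccc3CCl)c2n1`: 2750 nM
Compound 2 `ClCc1ccc(Cn2cnc3c(Cl)nc(Cl)nc32)cc1`: 7240 nM

In a functional assay on SN12C cells (Homo sapiens) for cytotoxicity, read by sulforhodamine B assay, with a stated time of 48 h (a higher number here means a weaker inhibitor of growth, a lower number a stronger inhibitor of growth), compound 1 gives 2750 nM, the lower of the two numbers, while compound 2 gives 7240 nM, a gap beyond the usual scatter. Compound 3 `ClCc1ccccc1Cn1cnc2c(Cl)nc(Cl)nc21` has not yet been measured. It differs from compound 1 in one place: chloro in place of amino on an aromatic carbon. Among the measured compounds shown here, no single-change step is available to guide the guess, but the number is expected to rise modestly because compound 2 gives 7240 nM and also carries a chloro group in that place. Compound 3 is expected at 5000 nM, with a range from 2000 nM to 15000 nM. That is an expected step of a 1.8-fold higher number from compound 1 to compound 3 (0.26 log units; within the scatter).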

Compound 3, concentration for 50% growth inhibition: 720 nM
Beside the measured number, compound 3's estimate is 6.9-fold (0.84 log units) above it; measured number below the stated range.
By their numbers in this assay, from the lowest: compound 3; then compound 1; then compound 2.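

In this assay, chloro in place of amino on this aromatic carbon, between two ring nitrogen atoms, gives a 3.8-fold lower number from compound 1 to compound 3 (0.58 log units; beyond the scatter) on an otherwise unchanged structure. Among the compounds shown here, this is the first direct reading of this position: the group there matters for growth inhibition, and chloro goes with the lower number. No measurement shown accounts for the step. This single pair cannot show how far the trend extends. On these data alone, whether a methoxy group or a bromo group on the same carbon would follow chloro or amino remains open.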